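The source may report more compounds than this note shows. Statements on the series, on what has been measured and on what is new or still open speak of the compounds shown alone.

Measured compounds in this study:

compound 1, `COC(=O)N(C)CC#CCn1ccnc1`: in a functional assay on the whole organism for antagonist activity, with Mus musculus as the target (on this read-out higher numbers stand for an effect only at larger amounts of compound and lower numbers for an effect already at smaller amounts), compound 1 gives > 100 mg/kg, a limit of the assay rather than a number.
compound 2, `COC(=O)N(C)CC#CCN(C)C`: in this assay compound 2 gives > 30 mg/kg, again a limit of the assay.
compound 3, `O=C1NCCN1CC#CCn1ccnc1`: in this assay compound 3 gives > 100 mg/kg, also a limit.

Compound 1 and compound 2 differ in one place, namely (dimethylamino in place of 1H-imidazol-1-yl on a saturated chain carbon bound to a triple-bonded carbon). The step that this change made is a step that the two limits leave unreadable from compound 1 to compound 2, so its size cannot be read. Two of the three values sit at the limit of > 100 mg/kg in this assay, at which 2 of the 3 values shown sit, and one sits at the limit of > 30 mg/kg in this assay, at which 1 of the 3 values shown sits.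

Compound 4, `CN(C)CC#CCN1CCNC1=O`, has not yet been measured. It stands to compound 3 as compound 2 stands to compound 1: the change is dimethylamino in place of 1H-imidazol-1-yl on a saturated chain carbon bound to a triple-bonded carbon, the same change at the same place. How the core of compound 3 differs from the core of compound 1 is not broken down here.

Since every measured value is a limit, the expectation for compound 4 rests on those limits alone. The step from compound 3 to compound 4 is expected to be a number no higher from compound 3 to compound 4 (the limit leaves the size open), because compound 3 gives > 100 mg/kg and the earlier step is a step that the two limits leave unreadable from compound 1 to compound 2. For compound 4 in this assay the estimate is 100 mg/kg, expected to fall between 30 mg/kg and 300 mg/kg, most likely reported as a limit again.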

Compound 4, dose for half-maximal effect: > 100 mg/kg
Compound 4 ended at the assay's limit; the forecaster's own chance of this, stated with the estimate: 85%; the middle value lies on the limit itself.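

Compound 3 and compound 4 both end at a limit of the assay, so the step between them cannot be read, just as the step between compound 1 and compound 2 could not. The compounds shown leave open what dose any of the four needs in this assay, and whether dimethylamino in place of 1H-imidazol-1-yl shifts that dose at all.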